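Methyl for Cyano on the Aryl Ether Ring

A few compounds are considered here, and "the series" means these few. Any claim that something is new, unique, unknown or untested is made for them only; others in the source may bear on it.

For the measured compounds named here, compound 2 `Cc1ccc(Nc2nc(N)nc(COc3cc(C#N)cc(N4CCCC4=O)c3)n2)cc1Cl` gives 4170 nM in an assay on COS-7 cells for agonist activity at Free fatty acid receptor 1 (Homo sapiens), read by scintillation counting and inositol phosphate accumulation, with a stated time of 90 min (on this read-out lower numbers stand for an effect already at smaller amounts and higher numbers for an effect only at larger amounts of compound), the highest of the two numbers measured so far. Compound 1 `COc1cc(OCc2nc(N)nc(Nc3ccc(C)c(Cl)c3)n2)cc(N2CCCC2=O)c1` gives 1800 nM, and the change from methoxy to cyano produced a 2.3-fold higher number from compound 1 to compound 2 (0.36 log units; beyond the scatter). Compound 3 `Cc1cc(OCc2nc(N)nc(Nc3ccc(C)c(Cl)c3)n2)cc(N2CCCC2=O)c1` differs from compound 2 by methyl in place of cyano on an aromatic carbon. Going by the values given here, no measured step exchanges cyano for methyl; the only step available concerns methoxy against cyano and was modest in size. Compound 3 is therefore expected to show a modestly lower number, a 1.9-fold lower number from compound 2 to compound 3 (0.28 log units; within the scatter). Compound 3 is estimated at 2200 nM, expected to lie between 1000 nM and 5000 nM.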

Compound 3, half-maximal effective concentration: 20 nM
Compound 3: the middle estimate sits 110-fold (2.04 log units) above what was measured, and the stated range ends above it.
By their numbers in this assay, from the lowest: compound 3; then compound 1; then compound 2.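

In this assay this position proves far more responsive than the earlier exchange of methoxy for cyano suggested: methyl in place of cyano gives a 210-fold lower number from compound 2 to compound 3 (2.32 log units; beyond the scatter), and methyl in place of methoxy gives a 90-fold lower number from compound 1 to compound 3 (1.95 log units; beyond the scatter). Among the three groups compared on this aromatic carbon, methyl alone stands apart, while the other two differ only modestly. Nothing given here explains this gap. As far as these compounds go, it remains open whether an ethyl group, a chlorine atom or a trifluoromethyl group would keep the low number that methyl gives.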